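Aryl exchange on the ring nitrogen: compound 3 to compound 4

A few compounds are considered here, and "the series" means these few. Any claim that something is new, unique, unknown or untested is made for them only; others in the source may bear on it.

Compound 3 `CCc1cccc(CC)c1-n1nncc1CN1C(=O)C2(C(C#N)=C(N)Oc3c(N)cc4nc5ccccc5nc4c32)c2ccccc21` returns only a limit in an ADME assay on HUVEC cells (Homo sapiens) for antiproliferative activity, read by MTT assay, with a stated time of 48 h (on this read-out higher numbers stand for weaker inhibition and lower numbers for stronger inhibition), namely > 50000 nM. Compound 2 `Cc1cc(C)cc(-n2nncc2CN2C(=O)C3(C(C#N)=C(N)Oc4c(N)cc5nc6ccccc6nc5c43)c3ccccc32)c1` likewise gives a limit in this assay, > 50000 nM. Compound 1 `N#CC1=C(N)Oc2c(N)cc3nc4ccccc4nc3c2C12C(=O)N(Cc1cnnn1-c1ccccc1Br)c1ccccc12` gives 34200 nM in this assay. The recorded steps are an at least 1.4-fold higher number from compound 1 to compound 2 (0.16 log units; that floor lies within the scatter) and an at least 1.4-fold higher number from compound 1 to compound 3 (0.16 log units; that floor lies within the scatter), while a step that the two limits leave unreadable from compound 2 to compound 3. Of the three values shown, two sit at the limit of > 50000 nM in this assay, at which 2 of the 3 values shown sit.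

Compound 4 `N#CC1=C(N)Oc2c(N)cc3nc4ccccc4nc3c2C12C(=O)N(Cc1cnnn1-c1ccc([N+](=O)[O-])cc1[N+](=O)[O-])c1ccccc12` differs from compound 3 in that (2,4-dinitrophenyl in place of 2,6-diethylphenyl on an aromatic nitrogen). Going by the values given here, no measured step exchanges an alkyl-substituted phenyl for a nitro-substituted one, so the change has no direct precedent; the aryl exchanges measured so far, an at least 1.4-fold higher number from compound 1 to compound 2 (0.16 log units; that floor lies within the scatter) and an at least 1.4-fold higher number from compound 1 to compound 3 (0.16 log units; that floor lies within the scatter), read only as floors within the scatter. For compound 4 in this assay the expected step is therefore an at least 1.1-fold lower number from compound 3 to compound 4 (0.04 log units; that floor lies within the scatter), with no movement beyond the scatter anticipated. Compound 4 is estimated at 45000 nM, in the range 15000 nM to 150000 nM, with a substantial chance that this assay again returns only a limit.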

Compound 4, half-maximal inhibitory concentration: > 50000 nM
Compound 4 gave a limit, no number (the forecaster's own chance of this, stated with the estimate: 55%); middle value at least 1.1-fold (0.04 log units) from the limit.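

Nitro-bearing and alkyl-bearing aryl groups on the ring nitrogen now end at the same ceiling in this assay: the limit of > 50000 nM in this assay, at which 3 of the 4 values shown sit. Going by these compounds alone, the one readable step is an at least 1.4-fold higher number from compound 1 to compound 4 (0.16 log units; that floor lies within the scatter), so 2,4-dinitrophenyl is not separated from 2-bromophenyl, and the steps among compound 2, compound 3 and compound 4 cannot be read. Within the data shown here, the hydrogen-bond acceptors that enter with 2,4-dinitrophenyl therefore bring no number into the readable range, and compound 1 remains the only compound of the four with a measured number rather than a limit.

As far as these compounds go, whether 2,6-diethylphenyl, 3,5-dimethylphenyl and 2,4-dinitrophenyl differ from one another at all remains open, as the limit hides any such difference. Also open, from the compounds shown here alone, is how a phenyl carrying an amine or a carboxylic acid would read in this assay.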